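The source may hold more compounds than are shown below. What is called first, only, known or untested is meant among the compounds shown, and "the series" means these compounds.

Three compounds built on one shared core have been examined in a functional assay on DU-145 cells (Homo sapiens) for cytotoxicity, read by MTT assay; on this read-out lower numbers stand for stronger inhibition and higher numbers for weaker inhibition. Compound 1, `CC(C)=CC[C@@H](OC(=O)c1ccoc1)C1=CC(=O)c2c(O)ccc(O)c2C1=O`, reaches only the limit of > 100000 nM in this assay. Compound 2, `CC(=O)OCCC(=O)O[C@H](CC=C(C)C)C1=CC(=O)c2c(O)ccc(O)c2C1=O`, gives 15700 nM in this assay, and compound 3, `CC(=O)OCCO[C@H](CC=C(C)C)C1=CC(=O)c2c(O)ccc(O)c2C1=O`, gives 15500 nM. Compound 3 holds the lower of the two numbers, and its nearest neighbour is compound 2, separated by the step of a 1.0-fold lower number from compound 2 to compound 3 (0.01 log units; within the scatter), which stays within the scatter. The position of compound 1 rests on (the limit of > 100000 nM in this assay, at which 1 of the 3 values shown sits). Compound 4, `CC(C)=CC[C@@H](OC[C@@H](C)O)C1=CC(=O)c2c(O)ccc(O)c2C1=O`, has not been measured; it differs from compound 3 by 1-hydroxyethyl in place of acetoxymethyl on a saturated chain carbon bound to an oxygen on a saturated carbon. Going by the values given here, the step that bears most directly on this change is the one from compound 2 to compound 3, a change at the same oxygen on a saturated carbon, which produced no movement beyond the scatter. The two larger steps, an at least 6.3-fold lower number from compound 1 to compound 2 (0.80 log units; beyond the scatter) and an at least 6.4-fold lower number from compound 1 to compound 3 (0.80 log units; beyond the scatter), concern the furan-3-yl group and lie further from the present change. Among the compounds with values here, no measured step exchanges an acetoxymethyl group for a 1-hydroxyethyl group, and the step expected in this assay is a 1.0-fold lower number from compound 3 to compound 4 (0.01 log units; within the scatter), within the scatter. Compound 4 is estimated at 15000 nM, within a range from 6000 nM to 40000 nM.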

Compound 4, half-maximal inhibitory concentration: 14300 nM
Compound 4: the middle estimate sits 1.0-fold (0.02 log units) above what was measured; measured number inside the range.
By their numbers in this assay, from the lowest: compounds 4, 3 and 2 (each within the scatter of the next). At a limit, above all of these: compound 1.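

In this assay, replacing acetoxymethyl with 1-hydroxyethyl on a saturated chain carbon bound to an oxygen on a saturated carbon gives a 1.1-fold lower number from compound 3 to compound 4 (0.03 log units; within the scatter), so a change further out on this chain, bringing in 1 hydrogen-bond donor and 1 defined stereocentre, moves the number no more than the earlier change at the oxygen did. Replacing (2-acetoxyethyl)carbonyl with 2-hydroxypropyl on that oxygen gives a 1.1-fold lower number from compound 2 to compound 4 (0.04 log units; within the scatter), which shows that the two changes taken together also leave the number within the scatter. Of the new steps, the only one beyond the scatter is an at least 6.9-fold lower number from compound 1 to compound 4 (0.84 log units; beyond the scatter), and it rests on a limit rather than a number: the limit of > 100000 nM in this assay, at which 1 of the 4 values shown sits.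

The compounds shown leave open whether the opposite configuration at the 1-hydroxyethyl stereocentre would read the same. They also leave open whether an amine, a carboxylic acid or a longer chain at this place would stay within the scatter in this assay.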